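This account rests on a few compounds, and the source may have more. Where it says the series, first, only, none or still open, it means among the compounds named here.

Compound 1 `O=S(=O)(Nc1ncccn1)c1ccc2c(c1)OCC[C@@H]2c1ccc(C(F)(F)F)cc1-c1ccc(F)nc1`: 90700 ng.h/mL
Compound 2 `Cn1nccc1-c1cc(C(F)(F)F)ccc1[C@H]1CCOc2cc(S(=O)(=O)Nc3nccs3)ccc21`: 7810 ng.h/mL

In an ADME assay on the whole organism (Mus musculus, strain BALB/c), read by LC-MS, with a stated time of 24 h, at a dose of 10 mg/kg by the oral route (a higher number here means more compound in the circulation at the dose given, a lower number less compound in the circulation), compound 2 has the lower of the two numbers at 7810 ng.h/mL, a gap from compound 1 that lies beyond the scatter. Compound 3 `Cn1nccc1-c1cc(C(F)(F)F)ccc1[C@H]1CCOc2cc(S(=O)(=O)Nc3ncccn3)ccc21` differs from compound 2 in one place: pyrimidin-2-yl in place of 1,3-thiazol-2-yl on a sulfonamide nitrogen. For the measured compounds named here, no measured pair isolates this change. Compound 1 also carries pyrimidin-2-yl on a sulfonamide nitrogen and gives 90700 ng.h/mL, though it differs from compound 3 elsewhere. A rise is therefore expected, with an estimated step of a 3.6-fold higher number from compound 2 to compound 3 (0.55 log units; beyond the scatter). Compound 3 is estimated at 28000 ng.h/mL, within a range of 8000 ng.h/mL to 95000 ng.h/mL.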

Compound 3, area under the concentration-time curve: 55200 ng.h/mL
Estimate against measurement, compound 3: 2.0-fold (0.29 log units) below, and the stated range covers the measured number.
By their numbers in this assay, from the lowest: compound 2; then compounds 3 and 1 (each within the scatter of the next).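

For the compounds shown here, on the sulfonamide nitrogen, pyrimidin-2-yl in place of 1,3-thiazol-2-yl gives a 7.1-fold higher number from compound 2 to compound 3 (0.85 log units; beyond the scatter) in the only measured pair that isolates this change. With pyrimidin-2-yl held fixed, 1-methyl-1H-pyrazol-5-yl in place of 6-fluoropyridin-3-yl on an aromatic carbon gives a 1.6-fold lower number from compound 1 to compound 3 (0.22 log units; within the scatter) and so shows no clear change. Nothing measured here explains either result.

Going by these compounds, whether the sulfonamide change gives a similar step with 6-fluoropyridin-3-yl on the aromatic carbon remains open. So does how a pyridin-2-yl or a plain phenyl on the sulfonamide nitrogen would compare.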